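Triazole dioxolanes: nitro analogue of compound 2 without configuration

The source may report more compounds than this note shows. Statements on the series, on what has been measured and on what is new or still open speak of the compounds shown alone.

Compound 1 `COc1ccc(-c2cn(C[C@H]3COC(C)(C)O3)nn2)cc1`: in a functional assay on B16 cells (Mus musculus) for cytotoxicity, read by MTT assay, with a stated time of 48 h (a lower number here means a stronger inhibitor, a higher number a weaker inhibitor), compound 1 gives > 100000 nM, a limit of the assay.
Compound 2 `CC1(C)OC[C@H](Cn2cc(-c3ccc([N+](=O)[O-])cc3)nn2)O1`: compound 2 gives > 100000 nM, again a limit.
Compound 3 `Cc1ccc(C(O)c2cn(CC3COC(C)(C)O3)nn2)cc1`: compound 3 gives > 100000 nM, again a limit.

Compound 2 stands at the limit, as do the other two; no value in this series is a number. For the measured compounds named here, the one step between measured compounds, a step that the two limits leave unreadable from compound 1 to compound 2, is unreadable because of the limit of > 100000 nM in this assay, at which 3 of the 3 values shown sit. Compound 4 `CC1(C)OCC(Cn2cc(-c3ccc([N+](=O)[O-])cc3)nn2)O1` differs from compound 2 by the two compounds have the same atoms and bonds; at least one stereo element is drawn with a configuration in one of them and without one in the other: 1 of 1 stereo elements differ; a stereocentre at a saturated ring carbon is drawn S in compound 2 and without a configuration in compound 4. Going by the values given here, no measured pair bears on this change, and the measured steps give no size to expect. Compound 4 is therefore expected to stay at the limit, with a step that the limit leaves unreadable from compound 2 to compound 4 as a step of no readable size. The estimate for compound 4 is 200000 nM, within 100000 nM to 1000000 nM.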

Compound 4, half-maximal inhibitory concentration: > 100000 nM
Compound 4 gave a limit, no number; the forecaster's own chance of this, stated with the estimate: 90%; the middle value lies beyond the limit too.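

For the compounds shown here, compound 2 and compound 4 both stand at a limit, so no step between them can be read: the limit of > 100000 nM in this assay, at which 4 of the 4 values shown sit. The compounds shown leave open whether the configuration at the saturated ring carbon has any bearing on potency, as none of them gives a number.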